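Adding a Three-Atom Group to the Core of Compound 1

A few compounds are considered here, and "the series" means these few. Any claim that something is new, unique, unknown or untested is made for them only; others in the source may bear on it.

Compound 1, with the structure `Cc1cn2cccc(OCc3ccccc3)c2n1`, stands highest of the two measured compounds in a functional assay on the whole organism (stomach) for inhibition, with Canis familiaris (Canis lupus familiaris) as the target, at a dose of 2 mg/kg by the intravenous route (a lower number here means a weaker effect, a higher number a stronger effect of the compound at the dose given), where compound 1 gives 61%. Its nearest neighbour is compound 2, built as `Cc1nc2c(COc3ccccc3)cccn2c1C`, which in this assay gives 44%, a number lower by a margin beyond the usual scatter. The two differ in more than one place, so what separates them is not traced to a single change; only the two values themselves are known.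

The unmeasured compound 3, with the structure `[C-]#[N+]Cc1c(C)nc2c(OCc3ccccc3)cccn12`, follows from compound 1 by one change: a group of 3 heavy atoms (2 carbon, 1 nitrogen; no ring) in place of a hydrogen atom, on an aromatic carbon. The entering group carries one triple bond outside aromatic rings and no hydrogen-bond donors or acceptors.

Within the data shown here, no single-point step between measured compounds is available to anchor the size of this change. In this assay compound 3 is expected to land somewhat below compound 1, a step from compound 1 to compound 3 of about a number 11 percentage points lower from compound 1 to compound 3 (beyond the scatter), close to the edge of the scatter. The estimate for compound 3 in this assay is 50%, within a range from 30% to 70%.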

Compound 3, a percentage reported as inhibition, in the whole organism at one dose (the size of the read-out at that dose, not a potency): 94%
For compound 3 the middle estimate is 44 percentage points below the measured one; the whole stated range lies below it.
By their numbers in this assay, from the lowest: compound 2; then compound 1; then compound 3.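

In this assay, among these compounds, a group of 3 heavy atoms (2 carbon, 1 nitrogen; no ring) in place of a hydrogen atom on an aromatic carbon brings a number 33 percentage points higher from compound 1 to compound 3 (beyond the scatter) and is the first large step that can be traced to one place. Compound 1 and compound 2 differ in more than one place and could show nothing of the kind; this step shows that the aromatic carbon of the five-membered aromatic ring, next to the ring nitrogen and next to the ring atom that bears a methyl group, can take this group while the effect at the dose given rises. No measurement explains the gain, and which part of the entering group carries it cannot be told from one step. 

The compounds shown leave open how other groups would compare on this same aromatic carbon, such as an amine, a carboxylic acid or a longer chain. They also leave open whether the same group would raise the effect on the core of compound 2, or how the gain would change at other doses.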